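The compounds below may be only part of what the source reports. "The series", "measured", "known", "first", "only" and "open" are said of these compounds alone.

In a physicochemical assay for solubility, in phosphate buffer (a lower number here means a less soluble compound, a higher number a more soluble compound), compound 2 `CC(C)C(NC(=O)Cn1c(-c2ccccc2)cc2c(=O)n(N(C)C)c(=O)[nH]c2c1=O)C(=O)C(F)(F)F` gives 320 ug/mL. Among the three compounds measured so far it holds the second highest number. Compound 1 `CC(C)C(NC(=O)Cn1c(-c2ccccc2)ccc(N)c1=O)C(=O)C(F)(F)F` gives 490 ug/mL, which differs from compound 2 only within the scatter, so the two cannot be ranked against each other. Compound 3 `CC(C)C(NC(=O)Cn1c(-c2ccccc2)ccc(NC(=O)OCc2ccncc2)c1=O)C(=O)C(F)(F)F` gives 16 ug/mL, far lower than compound 2. For the measured compounds named here, the one measured step between two compounds that differ in a single place was large: a 31-fold lower number from compound 1 to compound 3 (1.49 log units; beyond the scatter).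

Compound 4 `CCOCCn1c(=O)[nH]c2c(=O)n(CC(=O)NC(C(=O)C(F)(F)F)C(C)C)c(-c3ccccc3)cc2c1=O` differs from compound 2 in one place: 2-ethoxyethyl in place of dimethylamino on an aromatic nitrogen. Going by the values given here, the only measured step concerns a different kind of change, a ((pyridin-4-yl)methoxy)carbonyl in place of hydrogen on a nitrogen on an aromatic ring, and it does not bear directly on swapping dimethylamino for 2-ethoxyethyl on an aromatic nitrogen. Among the compounds with values here, no measured pair shows what that swap does. With nothing pointing either way, the expected step is no larger than the scatter: a 1.3-fold lower number from compound 2 to compound 4 (0.11 log units; within the scatter). Compound 4 is therefore estimated at 250 ug/mL, with a likely range from 100 ug/mL to 600 ug/mL.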

Compound 4, solubility: 8 ug/mL
The estimate for compound 4 lay 31-fold (1.49 log units) above the measured number, outside the stated range (below it).
By their numbers in this assay, from the lowest: compounds 4 and 3 (each within the scatter of the next); then compounds 2 and 1 (each within the scatter of the next).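

In this assay, the aromatic nitrogen of the shared core proves to be a position where the group matters: 2-ethoxyethyl in place of dimethylamino gives a 40-fold lower number from compound 2 to compound 4 (1.60 log units; beyond the scatter) and this step lies beyond the scatter. For the compounds shown here, the only earlier step, between compound 1 and compound 3, concerned a different nitrogen, so this is the first sign that a change at this place can move the number so far, even though the two groups have the same counts of hydrogen-bond donors and acceptors and neither carries a net charge. Nothing measured here explains the step.

With only two groups shown on this nitrogen, it stays open whether the loss of dimethylamino or the arrival of 2-ethoxyethyl drives the step. A methyl group, a longer chain or a chain ending in a carboxylic acid at this place would help separate the two.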